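The compounds below may be only part of what the source reports. "The series", "measured", "known", "first", "only" and "open" are said of these compounds alone.

In a functional assay (Homo sapiens) for inhibition (a lower number here means a stronger inhibitor, a higher number a weaker inhibitor), compound 1 (`CSc1cccc(CSc2nc(-c3ccc(F)cc3)c(-c3ccncc3)[nH]2)c1`) gives 550 nM and compound 2 (`Fc1ccc(-c2[nH]c(SCCCc3ccccc3)nc2-c2ccncc2)cc1`) gives 470 nM, two values within the scatter of each other. Compound 3 (`C[S+]([O-])c1cc(CSc2nc(-c3ccc(F)cc3)c(-c3ccncc3)[nH]2)ccc1O`) departs from compound 1 in one place: a group of 10 heavy atoms (7 carbon, 2 oxygen, 1 sulfur; one six-membered aromatic ring of carbon only) in place of a group of 8 heavy atoms (7 carbon, 1 sulfur; one six-membered aromatic ring of carbon only), on a saturated chain carbon bound to a sulfur. For the measured compounds named here, no measured step between compounds in this set shows what such a change does. The step in this assay is therefore expected to stay within the scatter, with no firm direction. The estimated step is a 1.4-fold lower number from compound 1 to compound 3 (0.14 log units; within the scatter). For compound 3 the expected value is 400 nM, with an estimated range from 100 nM to 1600 nM.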

Compound 3, half-maximal inhibitory concentration: 2300 nM
Estimate against measurement, compound 3: 5.8-fold (0.76 log units) below; measured number above the stated range.
By their numbers in this assay, from the lowest: compounds 2 and 1 (each within the scatter of the next); then compound 3.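

In this assay, the place on the saturated chain carbon bound to a sulfur proves sensitive to this replacement of the 3-(methylsulfanyl)phenyl group, which gives a 4.2-fold higher number from compound 1 to compound 3 (0.62 log units; beyond the scatter), a step beyond the scatter. The earlier pair differed in more than one place and could not show this. Nothing at hand accounts for the loss. On these data alone, the entering group differs from the group it replaces in both its oxygens, so which of them matters stays open. As far as these compounds go, whether an amine on the same aromatic ring would be tolerated also stays open.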